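The compounds below may be only part of what the source reports. "The series", "measured", "known", "first", "only" and "open" are said of these compounds alone.

Measured compounds:
Compound 1 `COC(=O)c1ccc(C#CCCCCC(=O)c2ncc(-c3ccccn3)o2)cc1` gives 25 nM in an assay for inhibition of Fatty-acid amide hydrolase 1 (Rattus norvegicus); on this read-out lower numbers stand for stronger inhibition and higher numbers for weaker inhibition.
Compound 2 `O=C(CCCCC#Cc1ccncc1)c1ncc(-c2ccccn2)o1` gives 150 nM in this assay.

Of these two numbers in this assay, compound 2 stands at the higher one; compound 1 stands at the lower, and the gap between them lies beyond the usual scatter. Compound 3 `O=C(CCCCC#Cc1ccc([N+](=O)[O-])cc1)c1ncc(-c2ccccn2)o1` has not yet been measured. It differs from compound 2 in one place: 4-nitrophenyl in place of pyridin-4-yl on a triple-bonded carbon. Among the compounds with values here, no step between measured compounds is available for this exact exchange, so the expectation rests on what the two measured values show. Compound 1, which also carries a substituted phenyl on the triple-bonded carbon, gives 25 nM, whereas compound 2 with pyridin-4-yl gives 150 nM. On that basis a step toward lower numbers is expected for compound 3 in this assay, of the size a 3.8-fold lower number from compound 2 to compound 3 (0.57 log units; beyond the scatter). Compound 3 is therefore estimated at 40 nM, with a range from 12 nM to 130 nM.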

Compound 3, inhibition constant: 31 nM
Beside the measured number, compound 3's estimate is 1.3-fold (0.11 log units) above it, and the stated range covers the measured number.
By their numbers in this assay, from the lowest: compounds 1 and 3 (each within the scatter of the next); then compound 2.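

In this assay, within the data shown here, 4-nitrophenyl in place of pyridin-4-yl on the triple-bonded carbon gives a 4.8-fold lower number from compound 2 to compound 3 (0.68 log units; beyond the scatter), the first direct reading of an exchange at this place. Nitro in place of methoxycarbonyl on the aromatic carbon gives a 1.2-fold higher number from compound 1 to compound 3 (0.09 log units; within the scatter), so this read-out does not separate compound 1 from compound 3, and the two different groups serve equally well here. No measurement of any property of these groups accompanies the result, and neither step can be explained from the data shown.

The compounds shown leave open whether an unsubstituted phenyl, or a phenyl bearing a carboxylic acid or an amine, would give numbers like that of compound 3 or like that of compound 2. They also leave open how a longer chain would affect these numbers.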